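Series notes: allyl to 4-methylbenzyl on the ring nitrogen

The source may hold more compounds than are shown below. What is called first, only, known or untested is meant among the compounds shown, and "the series" means these compounds.

Compound 1 `CC1=CC(=O)/C(=C(/C)Nc2ccc3c(Cl)nn(C)c3c2)C(=O)O1` is measured in an ADME assay on RAW264.7 cells (Mus musculus) for cytotoxicity, read by resazurin assay, with a stated time of 48 h (on this read-out lower numbers stand for higher toxicity in this test and higher numbers for lower toxicity in this test), only as a limit, > 100000 nM. Compound 2 `C=CCn1nc(Cl)c2ccc(N/C(C)=C3\C(=O)C=C(C)OC3=O)cc21` likewise returns only a limit in this assay, > 100000 nM. Among the measured compounds shown here, the one step between measured compounds, a step that the two limits leave unreadable from compound 1 to compound 2, therefore cannot be read in size or direction; both values sit at the limit of > 100000 nM in this assay, at which 2 of the 2 values shown sit. Compound 2 thus stands at the top end of the reported range, with no number for it and no neighbour whose number would fix it.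

Compound 3 `CC1=CC(=O)/C(=C(/C)Nc2ccc3c(Cl)nn(Cc4ccc(C)cc4)c3c2)C(=O)O1` is awaiting measurement in this assay. It differs from compound 2 by 4-methylphenyl in place of vinyl on a saturated chain carbon bound to an aromatic nitrogen. For the measured compounds named here, the only measured step bears on the same position but is unreadable, so no size or direction can be drawn from it. The expectation for compound 3 is that it stays near the same limit, with the step of an at least 1.1-fold lower number from compound 2 to compound 3 (0.04 log units; that floor lies within the scatter) from compound 2 to compound 3 expected to lie within the scatter. The estimated half-maximal cytotoxic concentration for compound 3 is therefore 90000 nM, within 30000 nM to 300000 nM.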

Compound 3, half-maximal cytotoxic concentration: > 100000 nM
Compound 3: a limit, no number (the forecaster's own chance of this, stated with the estimate: 60%); middle value at least 1.1-fold (0.04 log units) away from the limit.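

In this assay compound 3 gives > 100000 nM, a limit and not a number. No step among compound 1, compound 2 and compound 3 can be read, because all three values are limits: the limit of > 100000 nM in this assay, at which 3 of the 3 values shown sit.

The compounds shown leave open whether allyl to 4-methylbenzyl changes the half-maximal cytotoxic concentration at all, and in which direction.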